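A few compounds are considered here, and "the series" means these few. Any claim that something is new, unique, unknown or untested is made for them only; others in the source may bear on it.

Measured compounds:
- compound 1 `COc1ccc(C[C@H]2COC(=O)[C@@H]2Cc2ccc(OCC(=O)N3CCCCC3)c(OC)c2)cc1OC`: in an ADME assay on HeLa cells (Homo sapiens) for cytotoxicity, read by MTT assay (a higher number here means a weaker inhibitor, a lower number a stronger inhibitor), compound 1 gives 293000 nM
- compound 3 `CCN(CC)C(=O)CCC(=O)Oc1ccc(C[C@H]2C(=O)OC[C@@H]2Cc2ccc(OC)c(OC)c2)cc1OC`: in this assay compound 3 gives 213000 nM
- compound 2 `COC(=O)[C@@H](NC(=O)CCC(=O)Oc1ccc(C[C@H]2C(=O)OC[C@@H]2Cc2ccc(OC)c(OC)c2)cc1OC)c1c[nH]c2ccccc12`: in this assay compound 2 gives only a limit, >= 600000 nM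

Compound 1 and compound 3 sit within the scatter of each other, as the step of a 1.4-fold lower number from compound 1 to compound 3 (0.14 log units; within the scatter) shows; the value of compound 2 is the limit (the limit of >= 600000 nM in this assay, at which 1 of the 3 values shown sits), not a number. Compound 4 `COc1ccc(C[C@H]2COC(=O)[C@@H]2Cc2ccc(OCc3cn(Cc4ccccc4)nn3)c(OC)c2)cc1OC` differs from compound 1 in one place: 1-benzyl-1H-1,2,3-triazol-4-yl in place of (piperidin-1-yl)carbonyl on a saturated chain carbon bound to an oxygen on an aromatic ring. Going by the values given here, the only measured step at this place, a 1.4-fold lower number from compound 1 to compound 3 (0.14 log units; within the scatter), swapped one group on that oxygen for another without a shift beyond the scatter, so no step beyond the scatter is expected here either. Compound 4 is therefore expected to give about 260000 nM (between 110000 nM and 600000 nM), a step of a 1.1-fold lower number from compound 1 to compound 4 (0.05 log units; within the scatter).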

Compound 4, half-maximal inhibitory concentration: 346000 nM
For compound 4 the middle estimate is 1.3-fold (0.12 log units) below the measured one, within the range that was stated.
By their numbers in this assay, from the lowest: compounds 3, 1 and 4 (each within the scatter of the next). At a limit, above all of these: compound 2.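

Compounds 1 and 3 both carry a carbonyl in the group on this oxygen. Here, on the saturated chain carbon, the carbonyl and the non-aromatic ring give way to 1-benzyl-1H-1,2,3-triazol-4-yl with its two aromatic rings, yet the result is a 1.2-fold higher number from compound 1 to compound 4 (0.07 log units; within the scatter) in this assay. So, for this pair, a very different group at this place gives no step beyond the scatter, and nothing shown explains why.

On these data alone, whether an amine or a carboxylic acid at this place would give a step beyond the scatter remains open.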